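This account rests on a few compounds, and the source may have more. Where it says the series, first, only, none or still open, it means among the compounds named here.

Measured in an ADME assay on the whole organism for pharmacokinetics, with Rattus norvegicus as the target; on this read-out lower numbers stand for narrower distribution and higher numbers for wider distribution into tissues:
- compound 1 `C[C@@H](CO)Oc1cc(Oc2ccc(C(=O)N(C)C)cc2)cc(C(=O)Nc2ccn(C)n2)c1`: 1.9 L/kg
- compound 2 `COC[C@H](C)Oc1cc(Oc2ccc(C(=O)N(C)C)cc2)cc(C(=O)Nc2cc[nH]n2)c1`: 1.1 L/kg

With only these two compounds measured, compound 1 gives 1.9 L/kg, and this lies within the usual scatter of compound 2 at 1.1 L/kg. Neither can be placed clearly ahead of the other in this assay.

Compound 3 `C[C@@H](CO)Oc1cc(Oc2ccc(C(=O)N3CCC3)cc2)cc(C(=O)Nc2ccn(C)n2)c1` has not yet been measured. It keeps the rest of compound 1 and carries azetidin-1-yl in place of dimethylamino on a carbonyl carbon. Within the data shown here, no measured pair of compounds shows what a single change does here, so the expectation rests on compound 1 at 1.9 L/kg and on the small size of the change. The expected step is a 1.1-fold lower number from compound 1 to compound 3 (0.05 log units; within the scatter), which is estimated to stay within the scatter, with no firm direction. For compound 3 the estimated value is 1.7 L/kg, with an expected range of 0.9 L/kg to 3 L/kg.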

Compound 3, volume of distribution at steady state in the Rattus norvegicus assay: 1.8 L/kg
For compound 3 the middle estimate is 1.1-fold (0.02 log units) below the measured one; measured number inside the range.
By their numbers in the Rattus norvegicus assay, from the lowest: compounds 2, 3 and 1 (each within the scatter of the next).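

Among these compounds, replacing dimethylamino with azetidin-1-yl on a carbonyl carbon gives the first single-change step in the Rattus norvegicus assay: a 1.1-fold lower number from compound 1 to compound 3 (0.02 log units; within the scatter), so this change cannot be told apart from the scatter on that read-out. In a physicochemical assay for solubility (a higher number here means a more soluble compound, a lower number a less soluble compound), the same change gives an at least 2.8-fold lower number from compound 1 to compound 3 (0.45 log units; beyond the scatter), so the two read-outs do not respond alike to it. In the physicochemical assay compound 3 gives 350000 nM. That step has no fixed size, since in the physicochemical assay compound 1 gives > 1000000 nM, which is a limit of the assay and not a number: the limit of > 1000000 nM in the physicochemical assay, at which 1 of the 2 values shown sits.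

The compounds shown leave open whether a larger ring on the same carbonyl carbon, such as pyrrolidin-1-yl or morpholin-4-yl, would also stay within the scatter in the Rattus norvegicus assay. They also leave open how large the step in the physicochemical assay really is.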